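Swapping the Pentyl Chain End for Cyclohexyl

The compounds below may be only part of what the source reports. "The series", "measured", "known", "first", "only" and "open" are said of these compounds alone.

Compound 1 `O=C1Nc2c(ccc(F)c2F)C1(c1ccc(O)cc1)c1cccs1`: 0.3 nM
Compound 2 `CCCCCC1(c2ccc(O)cc2)C(=O)Nc2c1ccc(F)c2F`: 1.1 nM

Among the compounds with values here, in a functional assay on PC-3 cells (Homo sapiens) for cytotoxicity, read by WST assay, with a stated time of 72 h (a lower number here means a stronger inhibitor, a higher number a weaker inhibitor), compound 2 gives 1.1 nM, the higher of the two numbers measured so far. Compound 3 `O=C1Nc2c(ccc(F)c2F)C1(CC1CCCCC1)c1ccc(O)cc1` has not yet been measured. It departs from compound 2 as follows: cyclohexyl in place of butyl on a saturated chain carbon bound to a saturated ring carbon. The same difference reads as pentyl to cyclohexylmethyl. Within the data shown here, only one measured step bears on this change, the modest 3.7-fold higher number from compound 1 to compound 2 (0.56 log units; beyond the scatter), and it replaced a different group with pentyl. A change beyond the scatter is therefore not expected in this assay, and no firm direction can be expected. The estimated step is a 1.2-fold lower number from compound 2 to compound 3 (0.09 log units; within the scatter). For compound 3 the expected value is 0.9 nM, with an estimated range of 0.3 nM to 2.8 nM.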

Compound 3, half-maximal inhibitory concentration: > 1000 nM
Compound 3: a limit, no number; the forecaster's own chance of this, stated with the estimate: 2%; middle value at least 1100-fold (3.04 log units) away from the limit.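

In this assay compound 3 gives > 1000 nM, which is a limit of the assay and not a number: the limit of > 1000 nM in this assay, at which 1 of the 3 values shown sits. Within the data shown here, on this saturated ring carbon, cyclohexylmethyl gives an at least 900-fold higher number from compound 2 to compound 3 (2.95 log units; beyond the scatter) and an at least 3300-fold higher number from compound 1 to compound 3 (3.52 log units; beyond the scatter), far larger than the modest step the earlier compounds showed. Thiophen-2-yl and pentyl both keep strong activity here, so this position does not accept every carbon group.

As far as these compounds go, whether a longer chain such as heptyl or a group such as cyclopentylmethyl would read like compound 2 or like compound 3 stays open. From the compounds shown here alone, the true value of compound 3 also remains unknown.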